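Swapping Methoxy for Chloro: Expected Binding of Compound 4

This account rests on a few compounds, and the source may have more. Where it says the series, first, only, none or still open, it means among the compounds named here.

Compound 1 `CCOc1cncc(N2C3CCNCC2CC3)c1`: 3 nM
Compound 2 `Clc1cncc(N2C3CCCC2CNCC3)c1`: 8.4 nM
Compound 3 `COc1cncc(N2CCCNCCC2)c1`: 1 nM

Of the compounds shown here, three have been measured in an assay (strain Wistar) for binding affinity to Neuronal acetylcholine receptor; alpha4/beta2 (Rattus norvegicus); on this read-out lower numbers stand for stronger inhibition and higher numbers for weaker inhibition. Compound 3 gives 1 nM, the lowest of the three numbers. Compound 1 stands nearest to it, with a higher number whose distance lies beyond the usual scatter, and compound 2 stands furthest, with a higher number still further beyond the scatter. Compound 1 and compound 2 differ from compound 3 in more than one place, so neither pair isolates a single change.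

Compound 4 `Clc1cncc(N2CCCNCCC2)c1` differs from compound 3 in one place only: chloro in place of methoxy on an aromatic carbon. Among the measured compounds shown here, no measured pair shows this exchange on its own. Compound 2 also carries a chloro group on its aromatic ring and gives 8.4 nM, but it sits on a different core, so its number cannot be read as the effect of the chloro group alone.

For the measured compounds named here, with no direct precedent, the step is expected to be small, at most modestly toward a higher number, and it may well stay within the scatter. The expected step from compound 3 to compound 4 is a 2.0-fold higher number from compound 3 to compound 4 (0.30 log units; within the scatter). Compound 4 is therefore estimated at 2 nM, within a range from 0.6 nM to 7 nM.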

Compound 4, half-maximal inhibitory concentration: 2 nM
Compound 4: middle estimate and measured number agree at the digits printed; the measured number falls inside the stated range.
By their numbers in this assay, from the lowest: compounds 3, 4 and 1 (each within the scatter of the next, the first and the last beyond it); then compound 2.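

In this assay, the exchange of methoxy for chloro on an aromatic carbon, two atoms from the ring nitrogen, can now be read on its own on a shared core, and it gives a 2.0-fold higher number from compound 3 to compound 4 (0.30 log units; within the scatter). Among the compounds shown here, the earlier compounds could not show this: compound 2 carries a chloro group on a different core, whereas this pair isolates the single change, so at this position the two groups cannot be told apart on this read-out, even though chloro has one heavy atom and no hydrogen-bond acceptor against the two heavy atoms and one hydrogen-bond acceptor of methoxy. Nothing available on these compounds offers an explanation for this result.

The compounds shown hold no pair that tests the same exchange on the core of compound 1 or on the core of compound 2, so it remains open whether the result carries over to either of them. On these data alone, it is also open what an amine, a carboxylic acid or a longer chain such as propoxy would give at this position on the core shared by compound 3 and compound 4.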